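A few compounds are considered here, and "the series" means these few. Any claim that something is new, unique, unknown or untested is made for them only; others in the source may bear on it.

Measured in a functional assay on PANC-1 cells (Homo sapiens) for inhibition, read by sulforhodamine B assay, with a stated time of 48 h; on this read-out lower numbers stand for stronger inhibition of growth and higher numbers for weaker inhibition of growth:
- Compound 1 `Cc1ccn2c(CN3CCCCC3)c(-c3ccccc3)nc2n1`: 20 nM
- Compound 2 `Oc1ccc(-c2nc3ncccn3c2CN2CCCCC2)cc1`: 200 nM
- Compound 3 `CC(C)(C)c1nc2ncccn2c1CN1CCCCC1`: 4510 nM

Compound 3 has the highest number of the three and so shows the weakest growth inhibition in this assay. Its nearest neighbour is compound 2, with a 23-fold higher number from compound 2 to compound 3 (1.35 log units; beyond the scatter), where tert-butyl stands in place of 4-hydroxyphenyl. Compound 4 `Cc1ccn2c(CN3CCCCC3)c(C(C)(C)C)nc2n1` keeps the tert-butyl of compound 3 and adds methyl in place of hydrogen on an aromatic carbon.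

Going by the values given here, no measured step isolates this methyl. Among the compounds with values here, the one step available concerns a different place in the molecule, so it says little about the size of the new step, though it does show that this series can move widely on a single change. Compound 1 carries the methyl and gives 20 nM, while compound 2 lacks it and gives 200 nM. That pair also differs in phenyl against 4-hydroxyphenyl, so it offers only a weak hint of a lower number with methyl present. A moderate step downward is therefore expected, though no change beyond the scatter remains possible. The estimated shift is a 2.3-fold lower number from compound 3 to compound 4 (0.35 log units; beyond the scatter). For compound 4 the expected value is 2000 nM, with an estimated range from 500 nM to 6000 nM.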

Compound 4, concentration for 50% growth inhibition: 960 nM
Compound 4: middle estimate off by 2.1-fold (0.32 log units), on the high side, and the stated range covers the measured number.
By their numbers in this assay, from the lowest: compound 1; then compound 2; then compound 4; then compound 3.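

Going by these compounds alone, compound 4 gives the first direct reading of this position: in this assay, methyl in place of hydrogen on an aromatic carbon of the six-membered aromatic ring gives a 4.7-fold lower number from compound 3 to compound 4 (0.67 log units; beyond the scatter), so this carbon does affect growth inhibition when tert-butyl is present. The new comparison with compound 1 holds that methyl constant and gives a 48-fold higher number from compound 1 to compound 4 (1.68 log units; beyond the scatter) for tert-butyl in place of phenyl, a large step set against the modest step from the methyl, which shows that in these compounds the choice of group at the other site counts for more than this methyl. No measurement shown gives a reason for either step.

The compounds shown leave open whether the methyl step keeps its size when phenyl stands in place of tert-butyl, which would show whether the two changes act independently. They also leave open whether an ethyl group, a methoxy group or an amine on the same aromatic carbon would lower the number further than methyl does, or raise it again.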